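Adding a Second Fluorine: Compound 2 to Compound 3

The source may report more compounds than this note shows. Statements on the series, on what has been measured and on what is new or still open speak of the compounds shown alone.

Compound 1, `O=C(Nc1ccc(Oc2ccnc3[nH]ccc23)cc1)c1cc2cccnc2n(-c2ccc(F)cc2)c1=O`: 160 nM
Compound 2, `O=C(Nc1ccc(Oc2ccnc3[nH]ccc23)c(F)c1)c1cc2cccnc2n(-c2ccccc2)c1=O`: 160 nM

In a functional assay on HT-29 cells (Homo sapiens) for antiproliferative activity, read by MTT assay, with a stated time of 72 h (on this read-out higher numbers stand for weaker inhibition and lower numbers for stronger inhibition), compound 2 gives 160 nM, level at the digits shown with compound 1, which gives 160 nM in this assay; the two lie within the scatter of each other. Compound 3, `O=C(Nc1ccc(Oc2ccnc3[nH]ccc23)c(F)c1)c1cc2cccnc2n(-c2ccc(F)cc2)c1=O`, differs from compound 2 by fluoro in place of hydrogen on an aromatic carbon para to a large group, read one bond further out as phenyl to 4-fluorophenyl. For the measured compounds named here, no step between measured compounds isolates this change. Since compound 1 and compound 2 match with one fluoro in either place, the step in this assay is expected to be small, none beyond the scatter. Compound 3 is estimated at 150 nM, range 60 nM to 400 nM. The expected step is a 1.1-fold lower number from compound 2 to compound 3 (0.03 log units; within the scatter).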

Compound 3, half-maximal inhibitory concentration: 36 nM
The estimate for compound 3 lay 4.2-fold (0.62 log units) above the measured number, outside the stated range (below it).
By their numbers in this assay, from the lowest: compound 3; then compounds 1 and 2 (each within the scatter of the next).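

In this assay, fluoro in place of hydrogen on an aromatic carbon para to a large group is no silent change once the other fluoro is present: it gives a 4.4-fold lower number from compound 2 to compound 3 (0.65 log units; beyond the scatter). The other fluoro, added to a compound already carrying the 4-fluorophenyl, likewise gives a 4.4-fold lower number from compound 1 to compound 3 (0.65 log units; beyond the scatter), so the pair reaches a level that neither single fluoro reached. No measurement here bears on the reason for these steps.

The compounds shown leave open whether a chloro, a methyl or a methoxy in the same place would give a similar step. They also leave open how a compound with hydrogen in both places would read.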